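A Dimethylphenyl Replaces an Ethoxyphenyl on the Ring Nitrogen

The source may hold more compounds than are shown below. What is called first, only, known or untested is meant among the compounds shown, and "the series" means these compounds.

Measured so far:
Compound 1 `N#CC1=C(N)Oc2c(N)cc3nc4ccccc4nc3c2C12C(=O)N(Cc1cnnn1-c1ccc(F)cc1)c1ccccc12`: > 50000 nM
Compound 2 `CCOc1ccc(-n2nncc2CN2C(=O)C3(C(C#N)=C(N)Oc4c(N)cc5nc6ccccc6nc5c43)c3ccccc32)cc1`: > 50000 nM

In an ADME assay on L02 cells (Homo sapiens) for antiproliferative activity, read by MTT assay, with a stated time of 48 h (a lower number here means a stronger inhibitor, a higher number a weaker inhibitor), compound 1 gives > 50000 nM, which is a limit of the assay and not a number. In the same assay compound 2 gives > 50000 nM, again a limit. The step from compound 1 to compound 2 is therefore a step that the two limits leave unreadable from compound 1 to compound 2; the change there was ethoxy in place of fluoro on an aromatic carbon. Both values sit at the limit of > 50000 nM in this assay, at which 2 of the 2 values shown sit, so compound 2 stands only at that limit, with no number of its own.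

Compound 3 `Cc1cc(C)cc(-n2nncc2CN2C(=O)C3(C(C#N)=C(N)Oc4c(N)cc5nc6ccccc6nc5c43)c3ccccc32)c1` has not yet been measured. It differs from compound 2 by 3,5-dimethylphenyl in place of 4-ethoxyphenyl on an aromatic nitrogen. Among the measured compounds shown here, the only measured step that touches this part of the molecule is the one from compound 1 to compound 2, and its size cannot be read, because both ends are limits. Nothing measured here points to any step beyond the usual scatter, in either direction. Compound 3 is therefore expected to sit at the limit as well, with an estimate of 70000 nM (range 30000 nM to 250000 nM). This corresponds to an expected step that the limit leaves unreadable from compound 2 to compound 3, that is, essentially none.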

Compound 3, half-maximal inhibitory concentration: > 50000 nM
Compound 3 was reported as a limit; the forecaster's own chance of this, stated with the estimate: 85%; the middle value does not contradict the limit.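

In this assay, among the compounds shown here, compound 1, compound 2 and compound 3 each give a limit of the assay and not a number, so no step among them can be read: the limit of > 50000 nM in this assay, at which 3 of the 3 values shown sit. The compounds shown leave open how the 4-fluorophenyl, 4-ethoxyphenyl and 3,5-dimethylphenyl groups compare on the aromatic nitrogen.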